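Removing the Benzoyl Group from a Hydroxyphenyl Amide

The source may report more compounds than this note shows. Statements on the series, on what has been measured and on what is new or still open speak of the compounds shown alone.

Compound 1 `O=C(Nc1ccccc1C(F)(F)F)C1CCc2ccccc2N1` gives 45500 nM in a functional assay on MDA-MB-231 cells (Homo sapiens) for cytotoxicity, read by sulforhodamine B assay, with a stated time of 72 h; a higher number here means a weaker inhibitor of growth, a lower number a stronger inhibitor of growth.
Compound 2 `O=C(Nc1ccccc1C(F)(F)F)C1CCc2ccccc2N1C(=O)c1ccccc1` gives 5290 nM in this assay.
Compound 3 `O=C(Nc1ccccc1O)C1CCc2ccccc2N1C(=O)c1ccccc1` gives 4210 nM in this assay.

All three measured compounds share a core and differ from one another in only one place at a time. Compound 2 and compound 3 differ in the group carried on the aromatic ring of the amide side: hydroxy in place of trifluoromethyl on an aromatic carbon. The step of a 1.3-fold lower number from compound 2 to compound 3 (0.10 log units; within the scatter) lies within the usual scatter, so the two compounds cannot be told apart in this assay.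

Compound 2 and compound 1 differ at the ring nitrogen: hydrogen in place of benzoyl on a nitrogen on an aromatic ring in a ring. Here the step is clear, an 8.6-fold higher number from compound 2 to compound 1 (0.93 log units; beyond the scatter), meaning the compound without the benzoyl group is a weaker inhibitor of growth.

Compound 4 `O=C(Nc1ccccc1O)C1CCc2ccccc2N1` has not yet been measured. It differs from compound 3 by hydrogen in place of benzoyl on a nitrogen on an aromatic ring in a ring, and the place of this change is described in exactly the same words as for the change from compound 2 to compound 1, so it is the same change made on the hydroxy-bearing core rather than the trifluoromethyl-bearing one.

Because the same change produced an 8.6-fold higher number from compound 2 to compound 1 (0.93 log units; beyond the scatter), the step from compound 3 to compound 4 is expected to be of similar size, an 8.6-fold higher number from compound 3 to compound 4 (0.93 log units; beyond the scatter). The expectation rests on a single prior example, so its width must be generous. Compound 4 is therefore estimated to give 36000 nM in this assay, most likely between 14000 nM and 90000 nM.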

Compound 4, concentration for 50% growth inhibition: 5260 nM
For compound 4 the middle estimate is 6.8-fold (0.84 log units) above the measured one; measured number outside the range, below it.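

On the core carrying hydroxy, hydrogen in place of benzoyl gives a 1.2-fold higher number from compound 3 to compound 4 (0.10 log units; within the scatter) in this assay, so the size of this change on the core carrying trifluoromethyl does not carry over to this core: the same change on two cores in this assay, an 8.6-fold higher number (0.93 log units; beyond the scatter) from compound 2 to compound 1 and a 1.2-fold higher number (0.10 log units; within the scatter) from compound 3 to compound 4, 6.9-fold (0.84 log units) apart, beyond the scatter of two such steps.

The second change tells the same story from the other side, since hydroxy in place of trifluoromethyl gives an 8.7-fold lower number from compound 1 to compound 4 (0.94 log units; beyond the scatter) when the ring nitrogen carries hydrogen, a clear step that does not appear when that nitrogen carries benzoyl: the same change on two cores in this assay, a 1.3-fold lower number (0.10 log units; within the scatter) from compound 2 to compound 3 and an 8.7-fold lower number (0.94 log units; beyond the scatter) from compound 1 to compound 4, 6.9-fold (0.84 log units) apart, beyond the scatter of two such steps.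

So in these four compounds the two changes cannot be treated as independent, each with a fixed size that can simply be added to the other, but the numbers do not show why they interact or whether the same would hold for other groups.

The compounds shown leave open whether another group on the aromatic carbon, such as an amine or a carboxylic acid, would follow hydroxy or trifluoromethyl when the ring nitrogen carries hydrogen. They also leave open how a group other than benzoyl on that nitrogen, such as acetyl or a longer chain, would behave on either core.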